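Restoring the Branched Linker and the Para-Acid Arrangement

A few compounds are considered here, and "the series" means these few. Any claim that something is new, unique, unknown or untested is made for them only; others in the source may bear on it.

Compound 1 (`CC(C)c1onc(-c2c(Cl)cccc2Cl)c1COc1ccc(N(C)Cc2ccc(OCCO)cc2)c(C(F)(F)F)n1`): in an assay on isolated protein for agonist activity at Bile acid receptor (Homo sapiens), read by FRET (a lower number here means that less compound is needed, a higher number that more compound is needed for the effect), compound 1 gives 164 nM.
Compound 2 (`CC(Nc1ccc(C(=O)O)cc1)c1ccc(OCc2c(-c3c(Cl)cccc3Cl)noc2C2CC2)nc1C(F)(F)F`): in this assay compound 2 gives 101 nM.
Compound 3 (`O=C(O)c1ccccc1OCc1ccc(OCc2c(-c3c(Cl)cccc3Cl)noc2C2CC2)nc1C(F)(F)F`): in this assay compound 3 gives 434 nM.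

Compound 3 carries the highest number of the three; compound 1 lies nearest to it and compound 2 furthest, both beyond the scatter. For the measured compounds named here, the only step among measured compounds that differ in one place is a 4.3-fold higher number from compound 2 to compound 3 (0.63 log units; beyond the scatter), a modest rise.

Compound 4 (`CC(Oc1ccc(C(=O)O)cc1)c1ccc(OCc2c(-c3c(Cl)cccc3Cl)noc2C2CC2)nc1C(F)(F)F`) differs from compound 3 by 1-(4-carboxyphenoxy)ethyl in place of (2-carboxyphenoxy)methyl on an aromatic carbon. Going by the values given here, this change brings back the branched ethyl linker and the carboxyl arrangement seen in compound 2, while keeping an oxygen link as in compound 3; no measured pair separates these two features, so the step is read mainly from the one available comparison. Because the related step of a 4.3-fold higher number from compound 2 to compound 3 (0.63 log units; beyond the scatter) was a rise, its reversal in the branched, four-carboxy arrangement is expected to lower the number again, an estimated step of a 3.3-fold lower number from compound 3 to compound 4 (0.52 log units; beyond the scatter). Compound 4 is therefore estimated at 130 nM, with a range from 50 nM to 400 nM.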

Compound 4, half-maximal effective concentration: 352 nM
Estimate against measurement, compound 4: 2.7-fold (0.43 log units) below; low and high end bracket the measured number.
By their numbers in this assay, from the lowest: compounds 2 and 1 (each within the scatter of the next); then compounds 4 and 3 (each within the scatter of the next).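

At this aromatic carbon, ortho to a trifluoromethyl group, replacing (2-carboxyphenoxy)methyl with 1-(4-carboxyphenoxy)ethyl gives a 1.2-fold lower number from compound 3 to compound 4 (0.09 log units; within the scatter), so the branched chain and the 4-carboxy arrangement, taken together with an oxygen link, do not reverse a 4.3-fold higher number from compound 2 to compound 3 (0.63 log units; beyond the scatter). With the branch and the carboxyl arrangement held fixed, 4-carboxyphenoxy in place of (4-carboxyphenyl)amino gives a 3.5-fold higher number from compound 2 to compound 4 (0.54 log units; beyond the scatter), which shows that the link atom alone accounts for a step beyond the scatter. No evidence accompanies these results to explain the difference between the amino and oxygen links.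

The branch and the carboxyl arrangement remain unseparated, as no single-place comparison isolates either one. From the compounds shown here alone, it also remains open whether a sulfur link or an amide link on the same branched carbon would track with compound 2 or with compound 4.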